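Swapping the Anilino Group for Butyl(methyl)amino

The source may hold more compounds than are shown below. What is called first, only, known or untested is meant among the compounds shown, and "the series" means these compounds.

Of the compounds shown here, three on a shared core have been measured in a functional assay on CHO-K1 cells for antagonist activity at transient receptor potential cation channel subfamily V member 1 (Homo sapiens), read by FLIPR; on this read-out higher numbers stand for weaker inhibition and lower numbers for stronger inhibition. Compound 1 `CC(C(=O)NCc1ccc(C(F)(F)F)nc1Nc1ccc(F)cc1)c1ccc(NS(C)(=O)=O)c(F)c1` gives 39.2 nM. Compound 2 `Cc1ccc(Nc2nc(C(F)(F)F)ccc2CNC(=O)C(C)c2ccc(NS(C)(=O)=O)c(F)c2)cc1C` gives 39.3 nM, and the step of a 1.0-fold higher number from compound 1 to compound 2 (0.00 log units; within the scatter) shows that these two cannot be told apart. Compound 3 `Cc1ccc(Cl)cc1Nc1nc(C(F)(F)F)ccc1CNC(=O)C(C)c1ccc(NS(C)(=O)=O)c(F)c1` gives 14 nM, the lowest of the three numbers, reached by the steps of a 2.8-fold lower number from compound 1 to compound 3 (0.45 log units; beyond the scatter) and a 2.8-fold lower number from compound 2 to compound 3 (0.45 log units; beyond the scatter), each a modest gain in inhibition.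

Compound 4 `CCCCN(C)c1nc(C(F)(F)F)ccc1CNC(=O)C(C)c1ccc(NS(C)(=O)=O)c(F)c1` is the next compound to be measured in this assay. Its difference from compound 3 is butyl(methyl)amino in place of (5-chloro-2-methylphenyl)amino on an aromatic carbon. None of the three measured steps bears directly on this change: each of them exchanges one six-membered aromatic ring for another on the same nitrogen, and all of them keep the ring and the hydrogen-bond donor that compound 4 gives up. Among the compounds with values here, the measured series therefore offers no direct precedent, only the observation that the identity of the aryl group shifts the number by modest amounts at most.

With the ring and the donor removed, compound 4 is expected to show a higher number than compound 3, with a step of an 8.6-fold higher number from compound 3 to compound 4 (0.93 log units; beyond the scatter) that is beyond the scatter but uncertain in size. For compound 4 the estimate in this assay is 120 nM, within a range from 25 nM to 600 nM.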

Compound 4, inhibition constant: 0.8 nM
For compound 4 the middle estimate is 150-fold (2.18 log units) above the measured one; measured number outside the range, below it.
By their numbers in this assay, from the lowest: compound 4; then compound 3; then compounds 1 and 2 (each within the scatter of the next).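

At the position on an aromatic carbon next to the ring nitrogen, the exchanges among compound 1, compound 2 and compound 3 had produced only modest steps in this assay, whereas butyl(methyl)amino gives an 18-fold lower number from compound 3 to compound 4 (1.24 log units; beyond the scatter) as well as a 49-fold lower number from compound 2 to compound 4 (1.69 log units; beyond the scatter) and a 49-fold lower number from compound 1 to compound 4 (1.69 log units; beyond the scatter) on the same shared core. Strong inhibition at this position therefore needs neither the six-membered aromatic ring of carbon only nor the hydrogen-bond donor, since compound 4 carries neither and its number is the lowest of the four, with every step to the others beyond the scatter. Nothing shown here accounts for the size of this gain.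

The change removes the ring and the donor together, so the compounds shown cannot say which of the two losses goes with the lower number, and a butylamino group, which keeps the hydrogen on the nitrogen, would separate them. Going by these compounds, how far the result depends on the chain itself also stays open, as the series holds no dimethylamino group, longer alkyl chain or piperidine ring in this place.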